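The source may hold more compounds than are shown below. What is called first, only, known or untested is meant among the compounds shown, and "the series" means these compounds.

Measured compounds:
compound 1, `C=CCn1ncc2c(Br)nc(Cc3ccccc3)n2c1=O`, in a functional assay for inhibition, with Homo sapiens as the target (on this read-out higher numbers stand for weaker inhibition and lower numbers for stronger inhibition), gives > 48000 nM, a limit of the assay.
compound 2, `C=CCn1ncc2c(C)nc(Cc3ccccc3)n2c1=O`, in this assay gives > 48000 nM, a limit of the assay.
compound 3, `Cn1ncc2cnc(Cc3ccccc3)n2c1=O`, in this assay gives > 48000 nM, a limit of the assay.

Among the compounds with values here, every value so far sits at the limit of > 48000 nM in this assay, at which 3 of the 3 values shown sit, so no compound separates from another. Within the data shown here, the one paired step, a step that the two limits leave unreadable from compound 1 to compound 2, is unreadable for that reason. Compound 2 therefore stands only at a limit, with no number of its own.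

The next compound, compound 4, `C=CCn1ncc2c(C)nc(C(C)C)n2c1=O`, differs from compound 2 by isopropyl in place of benzyl on an aromatic carbon. Among the measured compounds shown here, no measured step touches this group: the only measured step concerns methyl in place of bromo, and compound 3 shows only that a compound with the same benzyl group, but otherwise altered, also sits at the limit. There is thus no measured basis for expecting a gain, and the shared run of limits weighs toward compound 4 also reporting a limit.

The step from compound 2 to compound 4 is expected to be a step that the limit leaves unreadable from compound 2 to compound 4, not distinguishable from none. Compound 4 is estimated at 70000 nM, with an expected range from 20000 nM to 250000 nM.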

Compound 4, half-maximal inhibitory concentration: > 48000 nM
Compound 4 gave a limit, no number (the forecaster's own chance of this, stated with the estimate: 85%); the middle value lies beyond the limit too.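

In this assay no step can be read between compound 2 and compound 4, since both report only a limit: the limit of > 48000 nM in this assay, at which 4 of the 4 values shown sit. The compounds shown leave open whether any substitution on the shared core gives a measurable value in this series.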